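Hydroxy to amino on the pendant phenyl: cytotoxicity notes

The compounds below may be only part of what the source reports. "The series", "measured", "known", "first", "only" and "open" are said of these compounds alone.

Compound 1 `COc1ccc(-c2cc3ccccc3c(-c3cccc(N)c3)n2)cc1`: in an ADME assay on MCF-10A cells (Homo sapiens) for cytotoxicity, read by CCK-8 assay and cell counting, with a stated time of 72 h (a lower number here means a stronger inhibitor, a higher number a weaker inhibitor), compound 1 gives 18800 nM.
Compound 2 `COc1cc(OC)cc(-c2cc3ccccc3c(-c3cccc(O)c3)n2)c1`: in this assay compound 2 gives 6770 nM.

Compound 2 stands as the lowest of the two numbers; the nearest, compound 1, lies at a higher number, and that gap is beyond the scatter. Going by the values given here, no pair of measured compounds differs in one place only, so no single step is available. Compound 3 `COc1cc(OC)cc(-c2cc3ccccc3c(-c3cccc(N)c3)n2)c1` differs from compound 2 by amino in place of hydroxy on an aromatic carbon. Compound 1, which also carries an amino group, gives a higher number than compound 2. A step from compound 2 to compound 3 of a 1.3-fold higher number from compound 2 to compound 3 (0.12 log units; within the scatter) is expected, a small move toward a higher number, near the scatter. Compound 3 is estimated at 9000 nM, with a range from 3500 nM to 22000 nM.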

Compound 3, half-maximal inhibitory concentration: > 50000 nM
Compound 3: no number, only a limit (the forecaster's own chance of this, stated with the estimate: 5%); at least 5.5-fold (0.74 log units) between middle value and limit.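

Going by these compounds alone, the first direct reading of the 3-hydroxyphenyl to 3-aminophenyl change gives an at least 7.3-fold higher number from compound 2 to compound 3 (0.86 log units; beyond the scatter), in this assay. At this place, meta to a large group, hydroxy and amino therefore do not read alike on the shared core, although the counted donors and acceptors stay the same. Compound 3 gives > 50000 nM, a limit and not a number, and the step's full size stays unknown: the limit of > 50000 nM in this assay, at which 1 of the 3 values shown sits.

Going by these compounds, whether the same change moves the number on the core of compound 1 remains open. So does the reading of a carboxylic acid or a methylamino group at this place.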